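The source may report more compounds than this note shows. Statements on the series, on what has been measured and on what is new or still open speak of the compounds shown alone.

Measured in a functional assay on MCF7 cells (Homo sapiens) for antiproliferative activity, read by MTT assay, with a stated time of 72 h; a higher number here means a weaker inhibitor, a lower number a stronger inhibitor:
compound 1 `CCN1CCN(c2cc(C)c3cc(NC(=O)c4ccc(OC)cc4)ccc3n2)CC1` gives 7690 nM
compound 2 `CCN1CCN(c2cc(C)c3cc(NC(=O)c4ccc(Cl)c(Cl)c4)ccc3n2)CC1` gives 1380 nM
compound 3 `CCN1CCN(c2cc(C)c3cc(NC(=O)c4ccc(Br)cc4)ccc3n2)CC1` gives 5940 nM

Compound 3 holds the second highest of the three numbers: a 1.3-fold lower number from compound 1 to compound 3 (0.11 log units; within the scatter) places it next to compound 1, while a 4.3-fold higher number from compound 2 to compound 3 (0.63 log units; beyond the scatter) separates it from compound 2. Compound 4 `CCN1CCN(c2cc(C)c3cc(NC(=O)c4ccccc4Br)ccc3n2)CC1` differs from compound 3 only in 2-bromophenyl in place of 4-bromophenyl on a carbonyl carbon. Among the measured compounds shown here, no measured step moves a group from one position to another on that ring: a 5.6-fold lower number from compound 1 to compound 2 (0.75 log units; beyond the scatter) and a 4.3-fold higher number from compound 2 to compound 3 (0.63 log units; beyond the scatter) change which groups and how many are present, and a 1.3-fold lower number from compound 1 to compound 3 (0.11 log units; within the scatter) exchanges one group at a fixed position without leaving the scatter. The expected step of a 1.1-fold higher number from compound 3 to compound 4 (0.04 log units; within the scatter) is therefore none beyond the scatter. In this assay compound 4 is estimated at 6500 nM, within 2500 nM to 17000 nM.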

Compound 4, half-maximal inhibitory concentration: 27500 nM
Compound 4: the middle estimate sits 4.2-fold (0.63 log units) below what was measured; measured number above the stated range.
By their numbers in this assay, from the lowest: compound 2; then compounds 3 and 1 (each within the scatter of the next); then compound 4.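

In this assay, moving bromine from 4-bromophenyl to 2-bromophenyl on the carbonyl carbon, with the same atoms joined differently, gives a 4.6-fold higher number from compound 3 to compound 4 (0.67 log units; beyond the scatter), so the position of the group on this ring changes the number, not only the identity of the group. Compound 4 also separates from the other two, with a 3.6-fold higher number from compound 1 to compound 4 (0.55 log units; beyond the scatter) and a 20-fold higher number from compound 2 to compound 4 (1.30 log units; beyond the scatter), the latter the largest step in the series. No evidence on the cause of this shift is available. Open, as far as these compounds go, is whether the same rise appears with chloro, methyl or an amino group in place of the bromine of 2-bromophenyl.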